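A few compounds are considered here, and "the series" means these few. Any claim that something is new, unique, unknown or untested is made for them only; others in the source may bear on it.

Working notes on the series

Compound 1 `O=S(=O)(Nc1ccc2oc(-c3ccccc3)nc2c1)c1cccc(C(F)(F)F)c1` and compound 2 `O=S(=O)(Nc1ccc2oc(-c3ccccc3)nc2c1)c1cccc(F)c1` share one core, and compound 3 `O=S(=O)(Nc1ccc(-c2nc3ccccc3o2)cc1)c1ccc(F)cc1` carries the same atoms joined differently; how the two cores differ is not broken down here. In an assay on cells for inhibition of HSP60/HSP10 (Homo sapiens), with a stated time of 60 min (on this read-out lower numbers stand for stronger inhibition and higher numbers for weaker inhibition), compound 1 gives only a limit, > 100000 nM. In this assay compound 2 likewise gives only a limit, > 100000 nM. Among the compounds with values here, compound 3 is the one member with a number in this assay, 73000 nM.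

The change from compound 2 to compound 1, (trifluoromethyl in place of fluoro on an aromatic carbon), makes a step that cannot be read, a step that the two limits leave unreadable from compound 2 to compound 1, because the limit of > 100000 nM in this assay, at which 2 of the 3 values shown sit, holds both values.

Compound 4 `O=S(=O)(Nc1ccc(-c2nc3ccccc3o2)cc1)c1ccc(C(F)(F)F)cc1` is not yet measured in this assay. It stands to compound 3 as compound 1 stands to compound 2: trifluoromethyl in place of fluoro on an aromatic carbon. The change is the same kind of change but not the same one, since the leaving and entering groups sit meta to a large group in compound 1 and para to a large group in compound 4.

Within the data shown here, the only earlier instance of this kind of change left no readable size, so the expectation for compound 4 rests on compound 3 alone, whose value 73000 nM is the single number in this assay, and on the change being a small swap of one halogen for trifluoromethyl. The step from compound 3 to compound 4 is expected to be small, a 1.1-fold higher number from compound 3 to compound 4 (0.04 log units; within the scatter). Compound 4 is thus estimated at 80000 nM, with a likely range from 25000 nM to 250000 nM, and with a real chance that this assay returns only a limit.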

Compound 4, half-maximal inhibitory concentration: 50000 nM
Estimate against measurement, compound 4: 1.6-fold (0.20 log units) above; measured number inside the range.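

Trifluoromethyl in place of fluoro on an aromatic carbon, para to a large group, makes a 1.5-fold lower number from compound 3 to compound 4 (0.16 log units; within the scatter) in this assay, so on this core the two values stay no further apart than repeated measurements would. The same kind of change on the shared core of compound 1 and compound 2 yields no size that could be set against this step, because both of its values rest on one limit: the limit of > 100000 nM in this assay, at which 2 of the 4 values shown sit. Within the data shown here, the step therefore shows only that one swap on one core leaves the read-out within the scatter; it does not show that the swap would behave alike on the other core, and a single readable step makes no pattern for the series.

Left open is how an amine, a carboxylic acid or a nitrile in place of fluoro or trifluoromethyl would read in this assay, on either core. The compounds shown also hold no pair that differs in the core alone, so what the core itself contributes to the read-out stays an open question.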